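Changing the Amide Nitrogen Substituent of Compound 2

The source may hold more compounds than are shown below. What is called first, only, known or untested is meant among the compounds shown, and "the series" means these compounds.

Of the compounds shown here, two have been measured. Compound 1 `N#C/C(=C\c1cccc(Br)n1)C(=O)N[C@@H](CO)c1ccccc1` gives 2800 nM in a functional assay on MM1 cells (Homo sapiens) for antiproliferative activity, read by MTT assay, with a stated time of 72 h; a higher number here means a weaker inhibitor, a lower number a stronger inhibitor. Compound 2 `CCC(NC(=O)/C(C#N)=C/c1ccc(-c2cccc([N+](=O)[O-])c2)o1)c1ccccc1` is reported in this assay only as a limit, > 10000 nM, and no number stands behind it.

Compound 2 therefore sits at the weak end of what this assay can report, as the relevant entry shows: the limit of > 10000 nM in this assay, at which 1 of the 2 values shown sits. Within the data shown here, compound 1 is the only measured compound with a number, and the two compounds differ in several places at once, so no single step between measured compounds is available here.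

The step considered is from compound 2 to compound 3 `COc1cccc(CNC(=O)/C(C#N)=C/c2ccc(-c3cccc([N+](=O)[O-])c3)o2)c1`, which is to be measured in this assay. The change is 3-methoxybenzyl in place of 1-phenylpropyl on an amide-type nitrogen. Among the measured compounds shown here, nothing among the measured compounds isolates this change, so no direction of step beyond the scatter can be derived from them. Compound 3 is expected to give 9000 nM, with a range from 2500 nM to 30000 nM. This estimate means a step of an at least 1.1-fold lower number from compound 2 to compound 3 (0.04 log units; that floor lies within the scatter), which is expected to fall within the scatter rather than beyond it, with a substantial chance that compound 3 is again reported only as a limit.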

Compound 3, half-maximal inhibitory concentration: > 10000 nM
Compound 3: a limit, no number (the forecaster's own chance of this, stated with the estimate: 55%); middle value at least 1.1-fold (0.04 log units) away from the limit.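

Compound 2 and compound 3 are both reported in this assay only as limits, so no step can be read between them. The compounds shown leave open whether 3-methoxybenzyl in place of 1-phenylpropyl on an amide-type nitrogen changes antiproliferative activity at all, and how far either compound lies from the limit.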